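The compounds below may be only part of what the source reports. "The series", "measured", "known", "first", "only" and "open" are said of these compounds alone.

Measured compounds:
compound 1 `CN1CCC(c2ccc(OCc3ccccc3)c(C(=O)Nc3ccnnc3)c2)CC1` — 71000 nM
compound 2 `O=C(Nc1cccnc1)c1cc(C(F)(F)F)ccc1OCc1ccccc1` — < 1000 nM

Within the data shown here, in a physicochemical assay for solubility, measured as kinetic solubility (a higher number here means a more soluble compound, a lower number a less soluble compound), compound 1 gives 71000 nM, the one actual number in this set. For compound 2 the assay reports only a limit, < 1000 nM, and not a number; the limit of < 1000 nM in this assay, at which 1 of the 2 values shown sits, marks that point. Compound 1 therefore stands as the sole anchor. Compound 3 `O=C(Nc1ccnnc1)c1cc(N2CCC(O)CC2)ccc1OCc1ccccc1` differs from it by 4-hydroxypiperidin-1-yl in place of 1-methylpiperidin-4-yl on an aromatic carbon. Among the measured compounds shown here, because no measured pair separates these two groups, the size of the step cannot be read from data; a modest loss of solubility is expected, with a 3.6-fold lower number from compound 1 to compound 3 (0.55 log units; beyond the scatter) as the estimated step. Compound 3 is thus estimated at 20000 nM, between 5000 nM and 70000 nM.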

Compound 3, solubility: 28000 nM
For compound 3 the middle estimate is 1.4-fold (0.15 log units) below the measured one; the measured number falls inside the stated range.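

In this assay, among these compounds, the exchange of 1-methylpiperidin-4-yl for 4-hydroxypiperidin-1-yl gives the first measured step at this position, the aromatic carbon para to a benzyloxy group: a 2.5-fold lower number from compound 1 to compound 3 (0.40 log units; beyond the scatter). The swap thus costs only a modest part of the reading while the rest of the core stays the same. Nothing measured here accounts for the size of this step.

On these data alone, how a morpholin-4-yl group or a carboxylic acid on this carbon would read in this assay stays open. So does whether the step would hold with a different amide partner.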